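A few compounds are considered here, and "the series" means these few. Any claim that something is new, unique, unknown or untested is made for them only; others in the source may bear on it.

Working notes on the series, all read in a functional assay on A549 cells (Homo sapiens) for cytotoxicity, read by MTT assay, with a stated time of 48 h; a lower number here means a stronger inhibitor, a higher number a weaker inhibitor. Compound 1 `C=CCn1c(-c2ccc(OC)cc2COCOC)cc2ccccc2c1=O` gives only a limit of the assay, > 100000 nM. Compound 2 `C=CCn1c(-c2cc(OC)c(OC)cc2C=C)cc2ccccc2c1=O` gives 43200 nM. Compound 3 `C=CCn1c(-c2ccc(OC)cc2C=O)cc2ccccc2c1=O` gives 88100 nM, the higher of the two actual numbers, and the gap to compound 2 lies just beyond the scatter.

Compound 4 `C=CCn1c(-c2ccc(OC)cc2C=C)cc2ccccc2c1=O` carries vinyl in place of formyl on an aromatic carbon, ortho to a large group and meta to a methoxy group: vinyl in place of formyl on an aromatic carbon.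

For the measured compounds named here, no measured step makes this exchange. Going by the values given here, the one step at this place is an at least 1.1-fold lower number from compound 1 to compound 3 (0.05 log units; that floor lies within the scatter), and it is only a bound resting on a limit. The nearest guide is compound 2, which also carries vinyl but has a further methoxy group, and it stands at 43200 nM.

A small shift toward a lower number is therefore expected, with the estimated 1.6-fold lower number from compound 3 to compound 4 (0.20 log units; within the scatter) not clearly beyond the scatter. For compound 4 the estimated value is 55000 nM, with an expected range of 25000 nM to 100000 nM.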

Compound 4, half-maximal inhibitory concentration: 17200 nM
Beside the measured number, compound 4's estimate is 3.2-fold (0.50 log units) above it, and the stated range ends above it.
By their numbers in this assay, from the lowest: compound 4; then compound 2; then compound 3. At a limit, above all of these: compound 1.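

In this assay, for the compounds shown here, the exchange of formyl for vinyl on this aromatic carbon, ortho to a large group, gives the first step at this place with a readable size: a 5.1-fold lower number from compound 3 to compound 4 (0.71 log units; beyond the scatter). The further methoxy group of compound 2 also proves to matter in the vinyl pair, with hydrogen in its place giving a 2.5-fold lower number from compound 2 to compound 4 (0.40 log units; beyond the scatter). The earlier step at this carbon was only a floor within the scatter, whereas vinyl in place of (methoxymethoxy)methyl gives an at least 5.8-fold lower number from compound 1 to compound 4 (0.76 log units; beyond the scatter), still a floor resting on a limit of the assay: the limit of > 100000 nM in this assay, at which 1 of the 4 values shown sits.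

As far as these compounds go, whether an ethyl group, a longer alkenyl chain or an amine on this aromatic carbon would give a number lower than vinyl stays open. Also open, from the compounds shown here alone, is whether the step from formyl to vinyl keeps its size with the further methoxy group of compound 2 present.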